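Replacing the aromatic ring group of compound 2

A few compounds are considered here, and "the series" means these few. Any claim that something is new, unique, unknown or untested is made for them only; others in the source may bear on it.

Measured so far in a functional assay on MCF7 cells (Homo sapiens) for inhibition, read by MTT assay, with a stated time of 48 h (a lower number here means a stronger inhibitor, a higher number a weaker inhibitor), are three compounds:
Compound 1 `CCOC(=O)C1=C(N/C=N/c2nnc(S(N)(=O)=O)s2)Nc2[nH]nc(C)c2C1c1ccc(N(C)C)cc1` at 34500 nM
Compound 2 `CCOC(=O)C1=C(N/N=C(/C(=O)Br)c2ccc(Br)cc2)Nc2[nH]nc(C)c2C1c1ccc(N(C)C)cc1` at 61300 nM
Compound 3 `CCOC(=O)C1=C(N/C=N/c2ncc(-c3ccccc3)s2)Nc2[nH]nc(C)c2C1c1ccc(N(C)C)cc1` at 10100 nM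

Compound 2 at 61300 nM lies above compound 3 at 10100 nM on these numbers. Its nearest measured neighbour is separated by a 1.8-fold higher number from compound 1 to compound 2 (0.25 log units; within the scatter) so on that side it stands level.

Compound 4 `CCOC(=O)C(=NNC1=C(C(=O)OCC)C(c2ccc(N(C)C)cc2)c2c(C)n[nH]c2N1)C(=O)OCC` has not been measured. Its change from compound 2 is a group of 12 heavy atoms (7 carbon, 1 nitrogen, 4 oxygen; no ring) in place of a group of 12 heavy atoms (8 carbon, 1 nitrogen, 1 oxygen, 2 bromine; one six-membered aromatic ring of carbon only), on an amine nitrogen and it falls on an amine nitrogen, with no ring in the group that enters.

Two measured group swaps bear on this change. One is the step just given, and the other, on a double-bonded nitrogen, is a 3.4-fold lower number from compound 1 to compound 3 (0.53 log units; beyond the scatter) and so modest. Neither swap removes the ring alone, so the data cannot isolate that loss. No step beyond the scatter is therefore expected, and the estimate is a 1.6-fold lower number from compound 2 to compound 4 (0.21 log units; within the scatter) in size. Compound 4 is estimated at 38000 nM in this assay with an expected range from 13000 nM to 100000 nM as its span.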

Compound 4, half-maximal inhibitory concentration: 89800 nM
Compound 4: middle estimate off by 2.4-fold (0.37 log units), on the low side; the measured number falls inside the stated range.
By their numbers in this assay, from the lowest: compound 3; then compounds 1, 2 and 4 (each within the scatter of the next, the first and the last beyond it).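

In this assay, the ring-free group on the amine nitrogen gives a 1.5-fold higher number from compound 2 to compound 4 (0.17 log units; within the scatter), so swapping out the group with the six-membered aromatic ring of carbon only and both bromines produces no step beyond the scatter. Set against the group with the five-membered aromatic ring, the same ring-free group gives a 2.6-fold higher number from compound 1 to compound 4 (0.42 log units; beyond the scatter), a modest step, which shows that this position can register a difference between groups of similar size. No evidence is available on why either step has the size it does.

Going by these compounds, the loss of the ring and the gain in hydrogen-bond acceptors arrive together in compound 4, so their separate contributions remain open. On these data alone, how a carboxylic acid or an amine in the entering group would fare in this assay also remains open.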